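Swapping ethyl for hydrogen in compound 2

A few compounds are considered here, and "the series" means these few. Any claim that something is new, unique, unknown or untested is made for them only; others in the source may bear on it.

In a functional assay on MCF7 cells (Homo sapiens) for cytotoxicity, read by MTT assay, with a stated time of 72 h (a lower number here means a stronger inhibitor, a higher number a weaker inhibitor), the measured compounds read as follows.
Compound 1 `Cc1oc2ncnc(Nc3cccc(Cl)c3)c2c1C(=O)NCCO` gives > 1000000 nM as a limit of the assay, not a number.
Compound 2 `CCOC(=O)c1c(C)oc2ncnc(Nc3ccc(OCc4cccc(F)c4)c(Cl)c3)c12` gives 257000 nM as its value.
Compound 3 `CCOC(=O)c1c(C)oc2ncnc(Nc3ccccc3)c12` gives 851000 nM as its value.

Only two of these results are true numbers, and compound 2 holds the lower of them, so it is the stronger inhibitor of that pair. The gap up to compound 3 lies beyond the usual scatter of repeated measurements. Even so, compound 2 is a weak inhibitor in absolute terms.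

The next compound, compound 4 `Cc1oc2ncnc(Nc3ccc(OCc4cccc(F)c4)c(Cl)c3)c2c1C(=O)O`, keeps everything in compound 2 except one detail, described by hydrogen in place of ethyl on an oxygen next to a carbonyl group. Hydrogen stands in place of ethyl on an oxygen next to a carbonyl group, which turns ethoxycarbonyl into carboxy.

Among the compounds with values here, no measured pair shows this change directly, so any expectation is tentative. Compound 1 also lacks the ethoxycarbonyl group, and it differs from compound 2 elsewhere too. The result of compound 1 is > 1000000 nM, which is a limit of the assay. This gives slight support for expecting a modest move towards a higher number in this assay, and a result at the limit would be no surprise. The estimated change is a 1.6-fold higher number from compound 2 to compound 4 (0.19 log units; within the scatter) in size. Compound 4 is expected at about 400000 nM, with an estimated range from 100000 nM to 1000000 nM as its likely span.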

Compound 4, half-maximal inhibitory concentration: 46000 nM
Compound 4: the middle estimate sits 8.7-fold (0.94 log units) above what was measured; measured number outside the range, below it.
By their numbers in this assay, from the lowest: compound 4; then compound 2; then compound 3. At a limit, above all of these: compound 1.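

Swapping ethyl for hydrogen on an oxygen next to a carbonyl group, which turns ethoxycarbonyl into carboxy, gives a 5.6-fold lower number from compound 2 to compound 4 (0.75 log units; beyond the scatter) in this assay. Within the data shown here, this is the first comparison in the set that changes one place only, and it shows that this position affects the result and that carboxy gives a lower number here than ethoxycarbonyl, with compound 4 at 46000 nM. Compound 1 also lacks the ethoxycarbonyl group and differs elsewhere too, and it cannot show the size of any step, since its result is a limit and not a number: the limit of > 1000000 nM in this assay, at which 1 of the 4 values shown sits.

Still open, going by these compounds, is whether the lower number comes from the free carboxy itself or simply from the loss of ethyl, a question that a methyl ester, a longer chain such as butyl on the same oxygen, or a tetrazole in place of the carboxy could help to separate. On these data alone, this step also rests on a single pair, so it remains open whether the same swap would move the number the same way on compound 3, which differs from compound 2 in the group on its aniline nitrogen.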